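The source may report more compounds than this note shows. Statements on the series, on what has been measured and on what is new or still open speak of the compounds shown alone.

Working notes on the series. For the measured compounds named here, compound 3 `CC[C@@H](Nc1c(C#N)c(-c2ccc(-c3cccc(C)c3)cc2)nc2cnccc12)C(N)=O` gives 3 in a physicochemical assay for lipophilicity, read by HPLC, at pH 7.5 (on this read-out lower numbers stand for lower lipophilicity and higher numbers for higher lipophilicity), the lowest of the three numbers so far; compound 1 `CC[C@@H](Nc1c(C#N)c(-c2ccc(-c3ccccc3C(F)(F)F)cc2)nc2cnccc12)C(N)=O` gives 3.1 and compound 2 `CC[C@@H](Nc1c(C#N)c(-c2ccc(-c3ccccc3C(C)C)cc2)nc2cnccc12)C(N)=O` gives 3.5. Against compound 1 the gap is a number 0.10 log units lower from compound 1 to compound 3 (within the scatter), so the two sit together; against compound 2 it is a number 0.50 log units lower from compound 2 to compound 3 (beyond the scatter), a modest step beyond the scatter. Within the pair that share the same place of substitution the change is a number 0.40 log units higher from compound 1 to compound 2 (beyond the scatter).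

Compound 4 `CC[C@@H](Nc1c(C#N)c(-c2ccc(-c3ccccc3Cl)cc2)nc2cnccc12)C(N)=O` differs from compound 3 as follows: 2-chlorophenyl in place of 3-methylphenyl on an aromatic carbon. Going by the values given here, no measured step involves 2-chlorophenyl. Among the compounds with values here, the steps that bear on it are the two that exchange 3-methylphenyl for a 2-substituted phenyl: from compound 1 the move was a number 0.10 log units lower from compound 1 to compound 3 (within the scatter), within the scatter, and from compound 2 it was a number 0.50 log units lower from compound 2 to compound 3 (beyond the scatter). The exchange to 2-chlorophenyl is therefore expected to sit nearer the first of these, giving no step beyond the scatter, or at most a small rise, in this assay.

Compound 4 is estimated at 3.1 in this assay, within 2.7 to 3.5. The estimated step is a number 0.10 log units higher from compound 3 to compound 4 (within the scatter), inside the usual scatter.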

Compound 4, distribution coefficient: 2.9
For compound 4 the middle estimate is 0.20 log units above the measured one; the range from low to high includes it.
By their numbers in this assay, from the lowest: compounds 4, 3 and 1 (each within the scatter of the next); then compound 2.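

Chloro in place of trifluoromethyl gives a number 0.20 log units lower from compound 1 to compound 4 (within the scatter) in this assay and so does not separate these two groups on this read-out, while chloro in place of isopropyl gives a number 0.60 log units lower from compound 2 to compound 4 (beyond the scatter) and extends the separation of compound 2 to a third comparison. The exchange of 3-methylphenyl for 2-chlorophenyl gives a number 0.10 log units lower from compound 3 to compound 4 (within the scatter) even though both the group on the phenyl ring and its place change, so among the four compounds only 2-isopropylphenyl stands apart on this read-out. Nothing shown here gives a measured property that would explain why compound 2 stands apart.

The compounds shown leave open whether the result depends on the chloro group itself or on its place on the phenyl ring, a question that 3-chlorophenyl would address directly against 2-chlorophenyl. They also leave open how far this read-out would move with a phenyl ring bearing an amine or a carboxylic acid, or with a longer chain such as 2-butylphenyl in place of 2-isopropylphenyl.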